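Dropping a Methoxy Group: Expected Effect on Growth Inhibition

The compounds below may be only part of what the source reports. "The series", "measured", "known", "first", "only" and "open" are said of these compounds alone.

In a functional assay on HCT-116 cells (Homo sapiens) for inhibition, read by sulforhodamine B assay, with a stated time of 48 h (on this read-out lower numbers stand for stronger inhibition of growth and higher numbers for weaker inhibition of growth), three compounds have been measured:
compound 1 `COc1ccc(-c2cc(/C=C/C(=O)c3ccc(N)cc3)[nH]n2)cc1` gives 1380 nM
compound 2 `COc1cc(-c2cc(/C=C/C(=O)c3ccc(N)cc3)[nH]n2)cc(OC)c1OC` gives 1100 nM
compound 3 `COc1ccc(C(=O)/C=C/c2cc(-c3cc(OC)c(OC)c(OC)c3)n[nH]2)cc1OC` gives 880 nM

Compound 2 sits in the middle of these three numbers: the step of a 1.3-fold lower number from compound 2 to compound 3 (0.10 log units; within the scatter) is within the scatter, and the numbers of compound 1 and compound 2 are likewise close, so none of the three can be called more potent than another. Compound 4 `COc1ccc(-c2cc(/C=C/C(=O)c3ccc(N)cc3)[nH]n2)cc1OC` differs from compound 2 by hydrogen in place of methoxy on an aromatic carbon. For the measured compounds named here, no measured step removes a methoxy group; the only measured step alters the group on the carbonyl carbon, and compound 1, carrying just one methoxy group, lands near compound 2. Hence no change beyond the scatter is expected. Compound 4 is expected to give 1200 nM, between 600 nM and 2400 nM, which is expected to amount to a 1.1-fold higher number from compound 2 to compound 4 (0.04 log units; within the scatter).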

Compound 4, concentration for 50% growth inhibition: 1710 nM
Beside the measured number, compound 4's estimate is 1.4-fold (0.15 log units) below it; the range from low to high includes it.
By their numbers in this assay, from the lowest: compounds 3, 2, 1 and 4 (each within the scatter of the next).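

For the compounds shown here, until now no step touched the methoxy groups on this ring. In this assay, hydrogen in place of methoxy on this aromatic carbon, ortho to a methoxy group, gives only a small shift (a 1.6-fold higher number from compound 2 to compound 4 (0.19 log units; within the scatter)). Methoxy in place of hydrogen on an aromatic carbon of the same ring also stays small (a 1.2-fold higher number from compound 1 to compound 4 (0.09 log units; within the scatter)), so neither change separates these compounds.

The compounds shown leave open whether a hydroxy group, an amine or a longer chain on this aromatic carbon would move the number beyond the scatter. Nothing here offers a reason for these small shifts.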